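The source may report more compounds than this note shows. Statements on the series, on what has been measured and on what is new or still open speak of the compounds shown alone.

Compound 2, with the structure `CS(=O)(=O)N(COC(=O)c1ccccc1)c1ccc([N+](=O)[O-])cc1Oc1ccccc1`, is a nitro-substituted aryl sulfonamide carrying a benzoyloxymethyl group on the sulfonamide nitrogen. Among the compounds with values here, in an ADME assay on a cell-free system (plasma, Homo sapiens) for metabolic stability (a higher number here means that the compound lasts longer, a lower number that the compound disappears faster), compound 2 gives 0.0322 h, the lowest of the three numbers measured so far. Its nearest neighbour on the numbers is compound 1, with the structure `CCCCN(CCCC)Cc1cccc(C(=O)OCCOCn2cnc3c(=O)[nH]c(N)nc32)c1`, which in this assay gives 0.0383 h; the two values lie within the scatter of each other. The furthest is compound 3, with the structure `CCOC(=O)c1ccc(/N=N/N(C)C(=O)OCOC(=O)c2ccccc2)cc1`, which in this assay gives 0.783 h, a gap well beyond the scatter.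

Compound 4, with the structure `CC(C)(C)C(=O)OCN(c1ccc([N+](=O)[O-])cc1Oc1ccccc1)S(C)(=O)=O`, has not yet been measured in this assay. It differs from compound 2 in one place: tert-butyl in place of phenyl on a carbonyl carbon, so that the benzoyloxymethyl group becomes a (((tert-butyl)carbonyl)oxy)methyl group. Within the data shown here, no measured pair in this set shows the same change, so there is no step to lean on, and the three values together give no rule for how an ester part of this kind sets the half-life.

With that said, compound 4 is expected to hold up somewhat longer than compound 2 in this assay, by a step of a 3.1-fold higher number from compound 2 to compound 4 (0.49 log units; beyond the scatter), of a size that may just reach beyond the scatter. The estimated half-life of compound 4 is 0.1 h, with a likely range from 0.03 h to 0.4 h.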

Compound 4, half-life: 1.7 h
Beside the measured number, compound 4's estimate is 17-fold (1.23 log units) below it, and the stated range ends below it.
By their numbers in this assay, from the lowest: compounds 2 and 1 (each within the scatter of the next); then compound 3; then compound 4.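

Within the data shown here, compound 2 and compound 4 form the first pair in this set that differs in one place, and in this assay the change of phenyl to tert-butyl on a carbonyl carbon gives a 53-fold higher number from compound 2 to compound 4 (1.72 log units; beyond the scatter). The earlier compounds shown here differed in several places at once and could not show this, whereas here the rest of the structure stays the same, so a single change on the ester part is enough to produce a large step in half-life. Nothing at hand measures why a tert-butyl in this place goes with so much longer a half-life than a phenyl, and the size of the step remains without an explanation.

Among these compounds, this change appears in only one pair, so it remains open whether a step of this size would recur on another core or with another group in place of the sulfonamide part. As far as these compounds go, it also remains open how the half-life would respond to a methyl, an isopropyl, a longer chain, a cyclohexyl ring or an amine on that carbonyl carbon, and thus whether the step follows the ring, the branching or something else.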